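The source may report more compounds than this note shows. Statements on the series, on what has been measured and on what is new or still open speak of the compounds shown alone.

Values in a functional assay on PC-3 cells (Homo sapiens) for antiproliferative activity, read by MTT assay, with a stated time of 48 h; on this read-out higher numbers stand for weaker inhibition and lower numbers for stronger inhibition:
- compound 1 `COc1ccc(CN(C(=O)CSc2nncs2)c2cc(OC)c(OC)c(OC)c2)cc1`: 5530 nM
- compound 2 `COc1ccc(CN(C(=O)CSc2nc3ccccc3o2)c2cc(OC)c(OC)c(OC)c2)cc1`: 3530 nM
- compound 3 `COc1ccc(CN(C(=O)COc2ccc(OC)cc2)c2cc(OC)c(OC)c(OC)c2)cc1`: 66400 nM

Compound 1 has a close neighbour on these numbers, with a 1.6-fold lower number from compound 1 to compound 2 (0.19 log units; within the scatter), and a distant one, with a 12-fold higher number from compound 1 to compound 3 (1.08 log units; beyond the scatter). Compound 4 `COc1ccc(CN(C(=O)COc2cccc(Cl)c2)c2cc(OC)c(OC)c(OC)c2)cc1` is not yet measured. It carries 3-chlorophenoxy in place of (1,3,4-thiadiazol-2-yl)sulfanyl on a saturated chain carbon bound to a carbonyl carbon.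

Compound 3, with 4-methoxyphenoxy at that place, is the closest guide. Its other step is also large, at a 19-fold higher number from compound 2 to compound 3 (1.27 log units; beyond the scatter). Among the measured compounds shown here, only this one compound supports the comparison, so a large step towards weaker inhibition in this assay is expected, perhaps somewhat smaller. The expected step is a 7.2-fold higher number from compound 1 to compound 4 (0.86 log units; beyond the scatter). For compound 4 the estimated value is 40000 nM, with an expected range of 12000 nM to 110000 nM.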

Compound 4, half-maximal inhibitory concentration: 30500 nM
Compound 4: the middle estimate sits 1.3-fold (0.12 log units) above what was measured; the range from low to high includes it.
By their numbers in this assay, from the lowest: compounds 2 and 1 (each within the scatter of the next); then compound 4; then compound 3.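

With 3-chlorophenoxy at this place, inhibition is again weaker than with either sulfur-linked group, with a 5.5-fold higher number from compound 1 to compound 4 (0.74 log units; beyond the scatter) and an 8.6-fold higher number from compound 2 to compound 4 (0.94 log units; beyond the scatter), so the loss seen with compound 3 is not confined to 4-methoxyphenoxy. The group on the oxygen also counts, since 3-chlorophenyl in place of 4-methoxyphenyl gives a 2.2-fold lower number from compound 3 to compound 4 (0.34 log units; beyond the scatter), a modest recovery that leaves compound 4 far from compound 1. No measurement here accounts for these differences. Still open, on these data alone, is whether the linking atom or the ring drives the loss: the heteroaromatic rings sit only on sulfur, the benzene rings only on oxygen. A phenylsulfanyl group at this place would separate the two.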